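Same aryl swap on a fluorinated core

The source may hold more compounds than are shown below. What is called first, only, known or untested is meant among the compounds shown, and "the series" means these compounds.

Compound 1 `O=C(Nc1ccc(Oc2ccnc3[nH]ccc23)cc1)c1cn(-c2ccc(Br)cc2F)c2ccccc2c1=O` gives 1330 nM in a functional assay on A549 cells (Homo sapiens) for inhibition, read by MTT assay, with a stated time of 72 h; on this read-out higher numbers stand for weaker inhibition and lower numbers for stronger inhibition. Compound 2 `O=C(Nc1ccc(Oc2ccnc3[nH]ccc23)cc1)c1cn(-c2ccc(C(F)(F)F)cc2Cl)c2ccccc2c1=O` differs from it by 2-chloro-4-(trifluoromethyl)phenyl in place of 4-bromo-2-fluorophenyl on an aromatic nitrogen; in this assay compound 2 gives 2350 nM, a step of a 1.8-fold higher number from compound 1 to compound 2 (0.25 log units; within the scatter). Compound 3 `O=C(Nc1ccc(Oc2ccnc3[nH]ccc23)c(F)c1)c1cn(-c2ccc(Br)cc2F)c2ccccc2c1=O` carries a second core, which differs from the core of compound 1 by fluoro in place of hydrogen on an aromatic carbon; in this assay compound 3 gives 1150 nM, a step of a 1.2-fold lower number from compound 1 to compound 3 (0.06 log units; within the scatter). Compound 3 and compound 1 thus sit within the scatter of each other, while the gap from compound 3 to compound 2 lies beyond it.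

Compound 4 `O=C(Nc1ccc(Oc2ccnc3[nH]ccc23)c(F)c1)c1cn(-c2ccc(C(F)(F)F)cc2Cl)c2ccccc2c1=O` has not been measured. It differs from compound 3 by 2-chloro-4-(trifluoromethyl)phenyl in place of 4-bromo-2-fluorophenyl on an aromatic nitrogen, the same change as that made between compound 1 and compound 2, with the place described in identical terms, now carried out on the core of compound 3. For the measured compounds named here, only one earlier instance of this change is available, so the expectation rests on a single step. For compound 4 a step of a 1.8-fold higher number from compound 3 to compound 4 (0.25 log units; within the scatter) in this assay is expected, because the earlier instance gave a 1.8-fold higher number from compound 1 to compound 2 (0.25 log units; within the scatter). The estimate for compound 4 in this assay is therefore 2050 nM, expected to fall between 1000 nM and 4300 nM.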

Compound 4, half-maximal inhibitory concentration: 1620 nM
Compound 4: the middle estimate sits 1.3-fold (0.10 log units) above what was measured; measured number inside the range.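

For the compounds shown here, on the core of compound 3, the aryl swap gives a 1.4-fold higher number from compound 3 to compound 4 (0.15 log units; within the scatter) in this assay, and its size does not differ from that on the core of compound 1 beyond the scatter: the same change on two cores in this assay, a 1.8-fold higher number (0.25 log units; within the scatter) from compound 1 to compound 2 and a 1.4-fold higher number (0.15 log units; within the scatter) from compound 3 to compound 4, 1.3-fold (0.10 log units) apart, within the scatter of two such steps Read the other way, fluoro in place of hydrogen on an aromatic carbon gives a 1.5-fold lower number from compound 2 to compound 4 (0.16 log units; within the scatter), and this change also carries over between the two aryl groups: the same change on two cores in this assay, a 1.2-fold lower number (0.06 log units; within the scatter) from compound 1 to compound 3 and a 1.5-fold lower number (0.16 log units; within the scatter) from compound 2 to compound 4, 1.3-fold (0.10 log units) apart, within the scatter of two such steps All four steps lie within the scatter, so the agreement shows only that these two changes stay small together; it does not show that either change has a real effect in this assay, or that a larger step would carry across cores in the same way.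

Still open, as far as these compounds go, is whether the same transfer holds for an aryl group bearing an amine or a carboxylic acid, or for a longer alkyl chain in its place on the aromatic nitrogen. Also open, from the compounds shown here alone, is how chloro or methoxy would behave on the aromatic carbon that carries fluoro in compound 3.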